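From 5-bromo-1H-indol-3-yl to 4-(dimethylamino)phenyl

This account rests on a few compounds, and the source may have more. Where it says the series, first, only, none or still open, it means among the compounds named here.

Among the measured compounds shown here, in a functional assay on DU-145 cells (Homo sapiens) for inhibition, read by trypan blue exclusion, with a stated time of 96 h (on this read-out higher numbers stand for weaker inhibition of growth and lower numbers for stronger inhibition of growth), compound 2 (`O=C(/C(=C\c1c[nH]c2ccc(Br)cc12)SCc1ccc(F)cc1)c1ccc(Cl)cc1`) gives 50000 nM as the only actual number so far. Compound 3 (`CN(C)c1ccc(/C=C(/SCc2ccc(F)cc2)C(=O)c2ccc(Cl)cc2)cc1`) has 4-(dimethylamino)phenyl in place of 5-bromo-1H-indol-3-yl on a double-bonded chain carbon bound to a double-bonded chain carbon and is otherwise compound 2. For the measured compounds named here, no measured step covers this change, so the expectation leans on compound 1 (`CN(C)c1ccc(/C=C(/SCc2ccccc2Cl)C(=O)c2ccc(Cl)cc2)cc1`), which also carries 4-(dimethylamino)phenyl and reads > 100000 nM as a limit of the assay. The expected move (a 1.6-fold higher number from compound 2 to compound 3 (0.20 log units; within the scatter)) is small and towards weaker inhibition of growth, possibly no larger than the scatter, and a report of only a limit would be no surprise. For compound 3 the estimated value in this assay is 80000 nM (30000 nM to 150000 nM).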

Compound 3, concentration for 50% growth inhibition: 50000 nM
Compound 3: the middle estimate sits 1.6-fold (0.20 log units) above what was measured; the measured number falls inside the stated range.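

In this assay, 4-(dimethylamino)phenyl in place of 5-bromo-1H-indol-3-yl on a double-bonded chain carbon bound to a double-bonded chain carbon gives no change at the digits printed from compound 2 to compound 3 (within the scatter), so this single pair shows no separation between the two groups at this position. Among the compounds shown here, on a saturated chain carbon bound to a sulfur, 4-fluorophenyl in place of 2-chlorophenyl gives an at least 2.0-fold lower number from compound 1 to compound 3 (0.30 log units; that floor lies within the scatter), which provides the first actual number for a compound carrying 4-(dimethylamino)phenyl. Compound 1 stands only as a limit, so this step has a floor and no true size: the limit of > 100000 nM in this assay, at which 1 of the 3 values shown sits.

On these data alone, whether the swap at the double-bonded chain carbon reads the same with any other group on the saturated chain carbon remains open. Also open, as far as these compounds go, is how a morpholine or a carboxylic acid in place of the dimethylamino group would read on this growth measure.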